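Chloro in place of methoxy: expected cytotoxicity of compound 4

The compounds below may be only part of what the source reports. "The series", "measured", "known", "first", "only" and "open" are said of these compounds alone.

Three compounds share one core and differ only in the group on the outer phenyl ring. In an ADME assay on MT4 cells (Homo sapiens) for cytotoxicity, read by MTT assay, with a stated time of 5 days (on this read-out higher numbers stand for lower toxicity in this test and lower numbers for higher toxicity in this test), compound 3 `COc1ccc(-c2cc(-c3ccccc3O)nc(N)n2)cc1` gives 92200 nM, and compound 2 `Nc1nc(-c2ccc(F)cc2)cc(-c2ccccc2O)n1` gives 67500 nM; the step of a 1.4-fold higher number from compound 2 to compound 3 (0.14 log units; within the scatter) lies within the scatter. For compound 1 `Cc1ccc(-c2cc(-c3ccccc3O)nc(N)n2)cc1` the result > 128000 nM is a limit of this assay, not a number (the limit of > 128000 nM in this assay, at which 1 of the 3 values shown sits). Compound 4 `Nc1nc(-c2ccc(Cl)cc2)cc(-c2ccccc2O)n1` differs from compound 3 as follows: chloro in place of methoxy on an aromatic carbon. The steps of an at least 1.8-fold lower number from compound 1 to compound 2 (0.27 log units; that floor lies within the scatter) and an at least 1.3-fold lower number from compound 1 to compound 3 (0.14 log units; that floor lies within the scatter) likewise stay within the scatter, so no change beyond the scatter is expected from compound 3 to compound 4, giving a 1.4-fold lower number from compound 3 to compound 4 (0.15 log units; within the scatter). Compound 4 is estimated at 65000 nM, between 25000 nM and 130000 nM.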

Compound 4, half-maximal cytotoxic concentration: > 74700 nM
Compound 4 ended at the assay's limit; the forecaster's own chance of this, stated with the estimate: 15%; at least 1.1-fold (0.06 log units) between middle value and limit.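

In this assay, among these compounds, compound 4, with chloro on the outer ring, gives a limit and not a number: the limit of > 74700 nM in this assay, at which 1 of the 4 values shown sits. The one step that can be read is an at least 1.1-fold higher number from compound 2 to compound 4 (0.04 log units; that floor lies within the scatter), so swapping fluoro for chloro shows no change beyond the scatter. The steps to compound 4 from compound 3 and from compound 1 cannot be read, so no readable step at this position yet goes beyond the scatter.

As far as these compounds go, the true value of compound 4 remains open. So does whether an amine or a carboxylic acid at this place would move the number beyond the scatter.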